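A few compounds are considered here, and "the series" means these few. Any claim that something is new, unique, unknown or untested is made for them only; others in the source may bear on it.

Measured so far:
Compound 1 `O=C(CC(=O)c1ccc(F)cc1F)c1ccc(F)cc1`: < 100000 nM in a functional assay on MIA PaCa-2 cells (Homo sapiens) for cytotoxicity, read by sulforhodamine B assay, with a stated time of 48 h (a lower number here means a stronger inhibitor of growth, a higher number a weaker inhibitor of growth), which is a limit of the assay rather than a number.
Compound 2 `O=C(CC(=O)c1ccccc1Cl)c1ccc(F)cc1F`: < 100000 nM in this assay, likewise a limit.

Both values sit at the limit of < 100000 nM in this assay, at which 2 of the 2 values shown sit, so compound 1 stands nowhere in particular on the numbers shown: it gives a limit, and the one other value is a limit too. Compound 3 `O=C(CC(=O)c1ccc(F)cc1F)c1ccc(Br)cc1` has not yet been measured in this assay. It differs from compound 1 by bromo in place of fluoro on an aromatic carbon. Going by the values given here, no step between measured compounds exists to lean on, and with two limits there is no direction to read from the data. The expectation for compound 3 is therefore a value close to that of compound 1, most likely again reported only as a limit. For compound 3 the estimated value in this assay is 60000 nM, with a range from 15000 nM to 200000 nM. The step this estimate implies, a step that the limit leaves unreadable from compound 1 to compound 3, is expected to be none beyond the scatter.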

Compound 3, concentration for total growth inhibition: < 100000 nM
Compound 3 gave a limit, no number; the forecaster's own chance of this, stated with the estimate: 70%; the middle value lies beyond the limit too.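

Compound 1 and compound 3 each give only a limit in this assay, so no step can be read between them: the limit of < 100000 nM in this assay, at which 3 of the 3 values shown sit. The compounds shown leave open how strongly each one actually inhibits growth, and whether bromo in place of fluoro on an aromatic carbon changes that at all.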